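Adding a methyl to the unsaturated amide chain

The source may report more compounds than this note shows. Statements on the series, on what has been measured and on what is new or still open speak of the compounds shown alone.

Of the compounds shown here, three sharing one core have been measured in a functional assay on HeLa cells (Homo sapiens) for inhibition, read by MTT assay, with a stated time of 72 h; a higher number here means a weaker inhibitor, a lower number a stronger inhibitor. Compound 1 `C=CC(=O)Nc1cccc(Oc2nc(Nc3cccc(OC)c3)nc3ccsc23)c1` carries a vinyl group on the carbonyl carbon and gives 16400 nM. Compound 2 `COc1cccc(Nc2nc(Oc3cccc(NC(=O)C=C(C)C)c3)c3sccc3n2)c1` carries 2-methylprop-1-en-1-yl on that carbon and gives 26100 nM. Compound 3 `CC/C=C/C(=O)Nc1cccc(Oc2nc(Nc3cccc(OC)c3)nc3ccsc23)c1` carries but-1-en-1-yl and gives 29400 nM, the highest of the three numbers, although every step among them falls inside the scatter, so no ordering can be read from them: a 1.6-fold higher number from compound 1 to compound 2 (0.20 log units; within the scatter), a 1.8-fold higher number from compound 1 to compound 3 (0.25 log units; within the scatter), and a 1.1-fold higher number from compound 2 to compound 3 (0.05 log units; within the scatter).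

Compound 4 `COc1cccc(Nc2nc(Oc3cccc(NC(=O)/C=C/C(C)C)c3)c3sccc3n2)c1` differs from compound 3 by methyl in place of hydrogen on a saturated chain carbon bound to a double-bonded chain carbon and a saturated chain carbon. For the measured compounds named here, the steps that bear on this change are those in which the chain on the carbonyl carbon was built up: from vinyl to 2-methylprop-1-en-1-yl, from vinyl to but-1-en-1-yl, and between those two larger chains. None of them moved the number beyond the scatter. A further methyl on the chain is therefore expected to change this assay little, with at most a slight drift toward a higher number and no step beyond the scatter. Compound 4 is estimated at 35000 nM, with a range from 15000 nM to 80000 nM, which corresponds to an expected step of a 1.2-fold higher number from compound 3 to compound 4 (0.08 log units; within the scatter).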

Compound 4, half-maximal inhibitory concentration: 27000 nM
The estimate for compound 4 lay 1.3-fold (0.11 log units) above the measured number; low and high end bracket the measured number.
By their numbers in this assay, from the lowest: compounds 1, 2, 4 and 3 (each within the scatter of the next).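

In this assay, methyl in place of hydrogen on a saturated chain carbon bound to a double-bonded chain carbon and a saturated chain carbon gives a 1.1-fold lower number from compound 3 to compound 4 (0.04 log units; within the scatter) and so leaves no readable mark on the number, which shows that this chain position accepts the change from but-1-en-1-yl to 3-methylbut-1-en-1-yl without a step beyond the scatter. The new chain also cannot be told apart from the two other chains, with a 1.0-fold higher number from compound 2 to compound 4 (0.01 log units; within the scatter) and with a 1.6-fold higher number from compound 1 to compound 4 (0.22 log units; within the scatter), so all four groups on the carbonyl carbon, vinyl included, read alike in this assay and the added compound extends the flat picture to a branched chain end. Nothing measured here offers an explanation for this flat result.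

Going by these compounds, how an amine or a carboxylic acid at the end of the chain, or a longer chain such as hex-1-en-1-yl, would read at this position stays open, and so does whether any group on the carbonyl carbon can move the number beyond the scatter. The part played by the double bond also stays open, as every chain shown carries one.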